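Trimming the Chain of Compound 2

The source may report more compounds than this note shows. Statements on the series, on what has been measured and on what is new or still open speak of the compounds shown alone.

In a functional assay on HEL cells (Homo sapiens) (on this read-out higher numbers stand for lower toxicity in this test and lower numbers for higher toxicity in this test), compound 2 (`CCCCCCCCCCCc1cc2cn(COCCO)c(=O)nc2o1`) gives 132000 nM as the highest number of the three measured, with compound 3 (`CCCCCCCCc1cc2cn(COCCO)c(O)nc-2n1`) at 65000 nM and compound 1 (`CCCCCCCCCCc1cc2cn(COCCO)c(O)nc-2n1`) at 32000 nM on the same scale. Compound 4 (`CCCCCCCCCc1cc2cn(COCCO)c(=O)nc2o1`) differs from compound 2 by a single change (hydrogen in place of ethyl on a saturated chain carbon, nine bonds along the chain from an aromatic carbon) on its chain. For the measured compounds named here, only one measured step bears on this: the same exchange, eight bonds along the chain on the core of compound 1, gave a 2.0-fold higher number from compound 1 to compound 3 (0.31 log units; beyond the scatter) as a modest rise. That core differs from the core of compound 2, so the parallel is imperfect, yet a similarly modest upward step is expected in this assay for this change. Compound 4 is therefore estimated at 240000 nM (expected range 120000 nM to 480000 nM). Expressed as a step, this is an expected 1.8-fold higher number from compound 2 to compound 4 (0.26 log units; within the scatter).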

Compound 4, half-maximal cytotoxic concentration: >= 100000 nM
Compound 4: only a limit was reported; the forecaster's own chance of this, stated with the estimate: 25%; the middle value is on the limit's open side.
By their numbers in this assay, from the lowest: compound 1; then compound 3; then compound 2.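

In this assay compound 4 gives >= 100000 nM as a limit and not a number, so the step from compound 2 to compound 4 cannot be read. The compounds shown leave open whether this shorter chain on the core of compound 2 moves the number up, down or not at all.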